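The compounds below may be only part of what the source reports. "The series", "measured", "known", "first", "only" and "open" are said of these compounds alone.

In a functional assay on the whole organism with Rattus norvegicus as the target (on this read-out lower numbers stand for an effect already at smaller amounts and higher numbers for an effect only at larger amounts of compound), compound 3 `Cn1c(=N)sc2cc(OC(F)(F)F)ccc21` gives 5 mg/kg, the lowest of the two numbers available; compound 2 `Nc1nc2ccc(OCC(F)(F)C(F)(F)F)cc2s1` gives 7.5 mg/kg, a gap within the scatter, so the two cannot be put in order. Compound 1 `Nc1nc2ccc(I)cc2s1` reaches only a limit of this assay, > 10 mg/kg, and no number is known for it. Compound 4 `CNS(=O)(=O)CCn1c(=N)sc2cc(OC(F)(F)F)ccc21` has not yet been measured in this assay. It differs from compound 3 by (methylsulfamoyl)methyl in place of hydrogen on a saturated chain carbon bound to an aromatic nitrogen. Among the compounds with values here, no measured pair shows a change of this kind, so its effect cannot be read from the numbers at hand. A modest rise in dose, close to the edge of the scatter, is expected for the step of a 1.6-fold higher number from compound 3 to compound 4 (0.20 log units; within the scatter). Compound 4 is therefore estimated at 8 mg/kg, most likely between 3 mg/kg and 20 mg/kg.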

Compound 4, dose for half-maximal effect: 4 mg/kg
Beside the measured number, compound 4's estimate is 2.0-fold (0.30 log units) above it, and the stated range covers the measured number.
By their numbers in this assay, from the lowest: compounds 4, 3 and 2 (each within the scatter of the next). At a limit, above all of these: compound 1.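

In this assay, putting (methylsulfamoyl)methyl in place of hydrogen on a saturated chain carbon bound to an aromatic nitrogen gives a 1.3-fold lower number from compound 3 to compound 4 (0.10 log units; within the scatter). Within the data shown here, this is the first measured pair to test this place, and it shows that methyl can give way to the clearly bigger 2-(methylsulfamoyl)ethyl without a readable loss of effect. Nothing in the data at hand explains this result.

The compounds shown leave open what an amine, a carboxylic acid or a plain longer chain would do at this place. They also cannot tell whether any single part of the new group matters.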